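The source may hold more compounds than are shown below. What is called first, only, known or untested is meant among the compounds shown, and "the series" means these compounds.

Working notes on the series. Among the compounds with values here, the set rests on the core shared by compound 1 `Cn1c(-c2ccccc2)c(Cl)c2cc(C#N)c(C#N)cc21` and compound 2 `N#Cc1cc2c(Br)c(-c3ccccc3)n(O)c2cc1C#N`, which differ from each other in more than one place, so no single-change step between measured compounds can be drawn. In an assay on isolated protein for inhibition of Amine oxidase [flavin-containing] B (Homo sapiens), read by fluorescence (on this read-out higher numbers stand for weaker inhibition and lower numbers for stronger inhibition), compound 1 gives only a limit of the assay, > 100000 nM. In this assay, within the data shown here, compound 2 gives 11900 nM, the only number in the set so far, and therefore the sole reference point. The one other entry sits at the limit of > 100000 nM in this assay, at which 1 of the 2 values shown sits.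

Compound 3 `COc1ccc(-c2c(Br)c3cc(C#N)c(C#N)cc3n2O)cc1` is the next member and differs from compound 2 in one place: methoxy in place of hydrogen on an aromatic carbon, the methoxy entering para to a large group on the six-membered carbon ring. Among the measured compounds shown here, no measured pair in this set carries a change of this kind, so the expectation rests on compound 2 alone. The step from compound 2 to compound 3 in this assay is expected to be a 1.5-fold lower number from compound 2 to compound 3 (0.17 log units; within the scatter), toward somewhat stronger inhibition but not far beyond the scatter. Compound 3 is estimated at 8000 nM in this assay, with a range from 2500 nM to 25000 nM.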

Compound 3, half-maximal inhibitory concentration: 1520 nM
Compound 3: the middle estimate sits 5.3-fold (0.72 log units) above what was measured; measured number outside the range, below it.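

Methoxy in place of hydrogen, para to a large group on the six-membered carbon ring, is the first single-place change that can be read in this series, and in this assay it gives a 7.8-fold lower number from compound 2 to compound 3 (0.89 log units; beyond the scatter), toward stronger inhibition. Within the data shown here, this position therefore accepts an added group with a gain rather than a loss, which compound 2 alone, as the sole number in the set, could not show. Compound 1 still offers no number to compare with, only a limit of the assay, and the data give no measured property that would account for the gain: the limit of > 100000 nM in this assay, at which 1 of the 3 values shown sits.

A single step at a single position does not separate the part played by the oxygen from that of the methyl or of the size of the entering group, and a hydroxyl, a fluorine, an ethoxy or an amine at the same place would tell these apart. As far as these compounds go, whether the gain holds elsewhere on the same ring, or carries over to other variants of the shared core, remains open.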